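This account rests on a few compounds, and the source may have more. Where it says the series, first, only, none or still open, it means among the compounds named here.

Two endoperoxide acids were tested in a functional assay on MDA-MB-231 cells (Homo sapiens) for inhibition; on this read-out lower numbers stand for stronger inhibition of growth and higher numbers for weaker inhibition of growth. Compound 1, `C=C1CCC[C@H]2[C@](C)(CC[C@]3(C)CC[C@@H]([C@@H](C)C(=O)O)OO3)[C@@H](C)CC[C@]12C`, gives 1810 nM in this assay. Compound 2, `CC1=C(CC/C(C)=C/CC[C@@]2(C)CC[C@@H]([C@H](C)C(=O)O)OO2)C(C)(C)CCC1`, stands at the limit of this assay with > 100000 nM, a limit and not a measured number, so its activity is known only as falling beyond that mark (the limit of > 100000 nM in this assay, at which 1 of the 2 values shown sits). Compound 3, `CC1=C(CC/C(C)=C/CC[C@@]2(C)CC[C@H]([C@H](C)C(=O)O)OO2)C(C)(C)CCC1`, is related to compound 2 by the two compounds have the same atoms and bonds and differ only in configuration as drawn: 1 of 4 stereo elements differ; a stereocentre at a saturated ring carbon is drawn S in compound 2 and R in compound 3. Among the compounds with values here, with compound 2 at the limit, no step within the pair can be sized, and no step beyond the scatter is expected from this change alone. Compound 3 is therefore estimated at 80000 nM, between 20000 nM and 300000 nM, an expected step of an at least 1.2-fold lower number from compound 2 to compound 3 (0.09 log units; that floor lies within the scatter).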

Compound 3, concentration for 50% growth inhibition: > 5000 nM
Compound 3 ended at the assay's limit; the forecaster's own chance of this, stated with the estimate: 60%; the middle value does not contradict the limit.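

Within the data shown here, compound 2 and compound 3 both stand at limits of the assay and not at measured numbers, so no step between them can be read. The compounds shown leave open whether this single change in configuration alters growth inhibition at all.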